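Tert-butyl ester step carried onto the thiophene analogue

This account rests on a few compounds, and the source may have more. Where it says the series, first, only, none or still open, it means among the compounds named here.

Compound 1 `CC1=C(C(=O)OCC(C)C)C(c2ccco2)NC(=O)N1C` in an assay on membranes from HEK293 cells for displacement of a labelled ligand from adenosine receptor A2b (Homo sapiens), read by scintillation counting, with a stated time of 30 min, tested at 1 uM (on this read-out higher numbers stand for more inhibition at the one concentration tested (going by the name of the read-out) and lower numbers for less inhibition), gives 4%. Compound 2 `CC1=C(C(=O)OC(C)(C)C)C(c2ccco2)NC(=O)N1C` carries tert-butyl in place of isobutyl on an oxygen next to a carbonyl group and in this assay gives 26%, the step being a number 22 percentage points higher from compound 1 to compound 2 (beyond the scatter). Compound 3 `CC1=C(C(=O)OCC(C)C)C(c2ccsc2)NC(=O)N1C` in this assay gives 1%, a step of a number 3 percentage points lower from compound 1 to compound 3 (within the scatter); its core differs from the core of compound 1 by thiophen-3-yl in place of furan-2-yl on a saturated ring carbon. Compound 4 `CC1=C(C(=O)OC(C)(C)C)C(c2ccsc2)NC(=O)N1C` is not yet measured; it differs from compound 3 by tert-butyl in place of isobutyl on an oxygen next to a carbonyl group, the same change as from compound 1 to compound 2, and the place of the change is the same in words on both cores. For the measured compounds named here, only that one earlier instance is available. Going by the values given here, for compound 4 a step of a number 19 percentage points higher from compound 3 to compound 4 (beyond the scatter) is expected in this assay, resting on the single step of a number 22 percentage points higher from compound 1 to compound 2 (beyond the scatter) and on compound 3 giving 1%. Compound 4 is therefore estimated at 20%, between -5% and 42%.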

Compound 4, a percentage reported as inhibition, at one concentration (the size of the read-out at that concentration, not a potency): 35%
Compound 4: the middle estimate sits 15 percentage points below what was measured, and the stated range covers the measured number.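

In this assay the tert-butyl ester change carries over to the thiophen-3-yl core, with a number 34 percentage points higher from compound 3 to compound 4 (beyond the scatter), and the two instances agree: the same change on two cores in this assay, a number 22 percentage points higher (beyond the scatter) from compound 1 to compound 2 and a number 34 percentage points higher (beyond the scatter) from compound 3 to compound 4, 12 percentage points apart, within the scatter of two such steps. Thiophen-3-yl in place of furan-2-yl on the tert-butyl esters gives a number 9 percentage points higher from compound 2 to compound 4 (within the scatter), in line with the same change on the isobutyl esters: the same change on two cores in this assay, a number 3 percentage points lower (within the scatter) from compound 1 to compound 3 and a number 9 percentage points higher (within the scatter) from compound 2 to compound 4, 12 percentage points apart, within the scatter of two such steps. This shows transfer between these two cores only, at one concentration, and says nothing about potency or about cores beyond these two.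

Still open, on these data alone, is whether a cyclopropyl ester, a longer chain on the ester oxygen, or an amide in place of the ester would follow the tert-butyl ester. As far as these compounds go, a phenyl group in place of furan-2-yl and thiophen-3-yl on the saturated ring carbon is also open.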